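Trifluoromethoxy in place of methoxy, second occurrence

This account rests on a few compounds, and the source may have more. Where it says the series, first, only, none or still open, it means among the compounds named here.

Compound 1 `CCc1nn(C)c(CO/N=C\c2c(C)nn(C)c2Oc2ccc(OC)cc2)c1Cl`, compound 2 `CCc1nn(C)c(CO/N=C\c2c(C)nn(C)c2Oc2ccc(OC(F)(F)F)cc2)c1Cl` and compound 3 `COc1ccc(Oc2c(/C=N\OCc3c(Cl)c(-c4ccc(Cl)cc4)nn3C)c(C)nn2C)cc1` were run in a functional assay on SMMC-7721 cells (Homo sapiens) for inhibition, read by MTT assay, with a stated time of 72 h, tested at 25 uM; on this read-out higher numbers stand for more inhibition at the one concentration tested (going by the name of the read-out) and lower numbers for less inhibition. For compound 1 the read-out is a limit, < 80%. For compound 2 the read-out is likewise a limit, < 80%. For the measured compounds named here, compound 3 gives 80% in this assay, the only number among the three. The change trifluoromethyl in place of methyl on an oxygen on an aromatic ring gives a step that the two limits leave unreadable from compound 1 to compound 2, since both ends sit at the limit of < 80% in this assay, at which 2 of the 3 values shown sit. The cores of compound 1 and compound 3 differ by 4-chlorophenyl in place of ethyl on an aromatic carbon, and a number no lower from compound 1 to compound 3 (the limit leaves the size open). Compound 4 `Cc1nn(C)c(Oc2ccc(OC(F)(F)F)cc2)c1/C=N\OCc1c(Cl)c(-c2ccc(Cl)cc2)nn1C` carries the same change, (trifluoromethyl in place of methyl on an oxygen on an aromatic ring), made on compound 3, and has not yet been measured in this assay. The step of a number 5 percentage points lower from compound 3 to compound 4 (within the scatter) is expected because compound 3 stands at 80% while the earlier instance of the change is unreadable. Compound 4 is expected to give 75%, between 50% and 90%.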

Compound 4, a percentage reported as inhibition, at one concentration (the size of the read-out at that concentration, not a potency): 80%
Estimate against measurement, compound 4: 5 percentage points below; low and high end bracket the measured number.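

In this assay, on the core carrying 4-chlorophenyl, trifluoromethyl in place of methyl on an oxygen on an aromatic ring gives no change at the digits printed from compound 3 to compound 4 (within the scatter). This is one readable instance and does not show that the change behaves the same way on the core carrying ethyl, since the size of every step involving compound 1 or compound 2 cannot be read, their entries being limits and not numbers: the limit of < 80% in this assay, at which 2 of the 4 values shown sit. With trifluoromethoxy in place, 4-chlorophenyl in place of ethyl on an aromatic carbon gives a number no lower from compound 2 to compound 4 (the limit leaves the size open). Whether 4-chlorophenyl in place of ethyl acts alike with methoxy and with trifluoromethoxy also stays unsettled: the same change on two cores in this assay, a number no lower (the limit leaves the size open) from compound 1 to compound 3 and a number no lower (the limit leaves the size open) from compound 2 to compound 4; the limit leaves it open whether they differ.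

The compounds shown leave open how the read-out in this assay responds to an amine or a carboxylic acid in place of methoxy. They also leave open how it responds to a longer chain in place of ethyl.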